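Compound 3 to compound 4: losing the phenyl group

The source may hold more compounds than are shown below. What is called first, only, known or untested is meant among the compounds shown, and "the series" means these compounds.

Measured so far in a functional assay on KB cells (Homo sapiens) for cytotoxicity, read by MTT assay, with a stated time of 72 h; a higher number here means that more compound is needed for the effect, a lower number that less compound is needed:
compound 1 `COc1ccc(Nc2cc(C3CCCCC3)oc(=O)c2)cc1` gives 8.32 uM
compound 2 `COc1ccc(Nc2cc(/C=C/c3ccccc3)oc(=O)c2)cc1` gives 0.15 uM
compound 3 `COc1ccc(Nc2cc(-c3ccccc3)oc(=O)c2)cc1` gives 0.16 uM

Compound 3 stands level with compound 2, with a 1.1-fold higher number from compound 2 to compound 3 (0.03 log units; within the scatter), and far under compound 1 on the numbers. Compound 4 `COc1ccc(Nc2cc(C(C)C)oc(=O)c2)cc1` carries isopropyl in place of phenyl on an aromatic carbon, next to the ring oxygen: isopropyl in place of phenyl on an aromatic carbon.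

Among the measured compounds shown here, two measured steps bear on this change. Going from cyclohexyl to phenyl gave a 52-fold lower number from compound 1 to compound 3 (1.72 log units; beyond the scatter), and going from cyclohexyl to 2-phenylethenyl gave a 55-fold lower number from compound 1 to compound 2 (1.74 log units; beyond the scatter). Among these three compounds, the two with an aromatic ring on this carbon sit together and the one with cyclohexyl sits far higher, and none goes against this. Isopropyl has no ring, and no measured compound shows that case, so the closest guide is compound 1 at 8.32 uM. A large move to a higher number is therefore expected, and the estimated step is a 50-fold higher number from compound 3 to compound 4 (1.70 log units; beyond the scatter). For compound 4 the estimated value is 8 uM, with an expected range from 2 uM to 30 uM.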

Compound 4, concentration for half-maximal effect: > 30 uM
Compound 4 ended at the assay's limit; the forecaster's own chance of this, stated with the estimate: 10%; middle value at least 3.7-fold (0.57 log units) away from the limit.
By their numbers in this assay, from the lowest: compounds 2 and 3 (each within the scatter of the next); then compound 1. At a limit, above all of these: compound 4.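

In this assay compound 4 gives > 30 uM, which is a limit of the assay and not a number: the limit of > 30 uM in this assay, at which 1 of the 4 values shown sits. On the aromatic carbon next to the ring oxygen, isopropyl in place of phenyl gives an at least 180-fold higher number from compound 3 to compound 4 (2.27 log units; beyond the scatter), and isopropyl in place of 2-phenylethenyl gives an at least 200-fold higher number from compound 2 to compound 4 (2.30 log units; beyond the scatter). Isopropyl in place of cyclohexyl still gives an at least 3.6-fold higher number from compound 1 to compound 4 (0.55 log units; beyond the scatter), so the two groups without an aromatic ring are not equivalent here, and the one with no ring at all gives the highest reading of the four compounds.

As far as these compounds go, how far compound 4 lies beyond its limit remains unknown, and so does the full size of these steps. Also open, from the compounds shown here alone, is where a longer chain or an amine on this carbon would fall relative to these compounds.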